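Dihydropyrimidinone series: amide to ester at the carbonyl

The source may hold more compounds than are shown below. What is called first, only, known or untested is meant among the compounds shown, and "the series" means these compounds.

Measured compounds:
compound 1 `CCNC(=O)C1=C(C)NC(=O)NC1c1ccco1`, 2%
compound 2 `CCNC(=O)C1=C(C)NC(=O)NC1c1ccsc1`, 3%
compound 3 `CC1=C(c2ncc(C)o2)C(c2ccco2)NC(=O)N1`, 27%

In an assay on membranes from CHO cells for displacement of a labelled ligand from adenosine receptor A1 (Homo sapiens), read by scintillation counting, with a stated time of 60 min, tested at 1 uM (on this read-out lower numbers stand for less inhibition and higher numbers for more inhibition at the one concentration tested (going by the name of the read-out)), compound 1 gives the lowest of the three numbers. Compound 2 sits within the scatter of it (a number 1 percentage points higher from compound 1 to compound 2 (within the scatter)), while compound 3 is separated from it by a number 25 percentage points higher from compound 1 to compound 3 (beyond the scatter).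

Compound 4 `CCC(C)OC(=O)C1=C(C)NC(=O)NC1c1ccco1` is not yet measured. It differs from compound 1 by sec-butoxy in place of ethylamino on a carbonyl carbon. For the measured compounds named here, no measured step touches this carbonyl carbon. Going by the values given here, the only step bearing on the group attached to the double-bonded ring carbon is a number 25 percentage points higher from compound 1 to compound 3 (beyond the scatter), which exchanged the whole ethylcarbamoyl for an oxazole. The exchange of ethylamino for sec-butoxy keeps the carbonyl, so a smaller movement is expected, probably within the scatter. Compound 4 is expected to give 8%, in the range 0% to 30%, a step of a number 6 percentage points higher from compound 1 to compound 4 (within the scatter).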

Compound 4, a percentage reported as inhibition, at one concentration (the size of the read-out at that concentration, not a potency): 6%
Compound 4: middle estimate off by 2 percentage points, on the high side, within the range that was stated.
By their numbers in this assay, from the lowest: compounds 1, 2 and 4 (each within the scatter of the next); then compound 3.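

With the carbonyl kept, sec-butoxy in place of ethylamino gives a number 4 percentage points higher from compound 1 to compound 4 (within the scatter) in this assay. At this carbonyl carbon, then, losing the hydrogen-bond donor of ethylamino and moving to the larger sec-butoxy produces no step beyond the scatter, whereas the exchange of the whole ethylcarbamoyl gave a number 25 percentage points higher from compound 1 to compound 3 (beyond the scatter) on the same read-out. No evidence on hand bears on this result.

As far as these compounds go, whether a carboxylic acid or a longer chain at this carbonyl carbon would give a step beyond the scatter remains open. Also open, from the compounds shown here alone, is whether sec-butoxy gives the same reading with thiophen-3-yl in place of furan-2-yl.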